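The source may hold more compounds than are shown below. What is called first, only, known or untested is meant among the compounds shown, and "the series" means these compounds.

Compound 1 `O=C(Nc1ccc(Cl)cc1)Nc1cccc(CNc2nccnc2Cl)c1`: 5470 nM
Compound 2 `CN(C)c1ccc(NC(=O)Nc2cccc(CNc3nccnc3Cl)c2)cc1`: 20200 nM

In a functional assay on T-24 cells (Homo sapiens) for antiproliferative activity, read by MTT assay, with a stated time of 48 h (a lower number here means a stronger inhibitor, a higher number a weaker inhibitor), compound 2 has the higher of the two numbers, so it is the weaker inhibitor. Compound 3 `O=C(Nc1cccc(CNc2nccnc2Cl)c1)Nc1ccc(Cl)cc1Cl` has 2,4-dichlorophenyl in place of 4-(dimethylamino)phenyl on an amide-type nitrogen. Among the compounds with values here, only one measured step bears on this: a 3.7-fold higher number from compound 1 to compound 2 (0.57 log units; beyond the scatter), a modest change beyond the scatter, with dimethylamino in place of chloro on an aromatic carbon. Compound 3 reverses that swap and carries one further chloro, so a fall of similar or slightly larger size is expected. The expected change is a 4.8-fold lower number from compound 2 to compound 3 (0.68 log units; beyond the scatter). The estimate for compound 3 is 4200 nM, within an expected range of 1500 nM to 11000 nM.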

Compound 3, half-maximal inhibitory concentration: 5740 nM
The estimate for compound 3 lay 1.4-fold (0.14 log units) below the measured number; the range from low to high includes it.
By their numbers in this assay, from the lowest: compounds 1 and 3 (each within the scatter of the next); then compound 2.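

In this assay, 2,4-dichlorophenyl in place of 4-(dimethylamino)phenyl on the amide-type nitrogen gives (a 3.5-fold lower number from compound 2 to compound 3 (0.55 log units; beyond the scatter)), so the step away from dimethylamino also holds with a second chloro on the ring. That extra chloro, in place of hydrogen on an aromatic carbon, gives (a 1.0-fold higher number from compound 1 to compound 3 (0.02 log units; within the scatter)), which places compound 1 and compound 3 within the scatter of each other. No measurement shown here accounts for these numbers. From the compounds shown here alone, whether a fluoro, a methoxy or a carboxylic acid on this ring would stand with the chloro compounds or with compound 2 remains open.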